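The source may report more compounds than this note shows. Statements on the series, on what has been measured and on what is new or still open speak of the compounds shown alone.

Among the measured compounds shown here, compound 2 `CC1=NN(C(=O)c2cc3ccccc3oc2=O)C(=O)C1CNc1cccc(S(N)(=O)=O)c1` stands highest of the two numbers so far in a functional assay on the whole organism for inhibition, with Rattus norvegicus as the target, read by paw edema, with stated times of 1 h and 6 h, at a dose of 0.03 mg/kg by the oral route (on this read-out higher numbers stand for more inhibition at the one dose given (going by the name of the read-out) and lower numbers for less inhibition), where compound 2 gives 79.9%. For the measured compounds named here, compound 1 `CC1=NN(C(=O)c2cc3ccccc3oc2=O)C(=O)C1CNc1ccccn1` gives 50.3% in this assay, and the one measured step, a number 29.6 percentage points higher from compound 1 to compound 2 (beyond the scatter), concerns a different exchange on the same amine nitrogen. Compound 3 `CC1=NN(C(=O)c2cc3ccccc3oc2=O)C(=O)C1CNc1ccc(S(N)(=O)=O)cc1` differs from compound 2 by 4-sulfamoylphenyl in place of 3-sulfamoylphenyl on an amine nitrogen. Going by the values given here, no measured step moves the sulfamoyl group within the phenyl ring, so that step only says the number is higher with the group present than with pyridin-2-yl; a shift within the scatter, in either direction, is expected. For compound 3 the estimate is 75%, within 55% to 92%, which is expected to mean a number 4.9 percentage points lower from compound 2 to compound 3 (within the scatter).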

Compound 3, a percentage reported as inhibition, in the whole organism at one dose (the size of the read-out at that dose, not a potency): 77.9%
Compound 3: the middle estimate sits 2.9 percentage points below what was measured, and the stated range covers the measured number.
By their numbers in this assay, from the lowest: compound 1; then compounds 3 and 2 (each within the scatter of the next).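

With 4-sulfamoylphenyl in place of 3-sulfamoylphenyl on the amine nitrogen, this assay shows no readable separation between the two groups, with a number 2 percentage points lower from compound 2 to compound 3 (within the scatter). The gain over pyridin-2-yl therefore holds for both sulfamoylphenyl groups, with a number 27.6 percentage points higher from compound 1 to compound 3 (beyond the scatter). Nothing at hand bears on the reason for this. Open, on these data alone, is whether the sulfamoyl group itself carries the gain: unsubstituted phenyl, or a phenyl bearing a carboxylic acid instead, would separate its part from that of the ring exchange.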